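Cytotoxicity at the Assay Limit Across Three Analogues

A few compounds are considered here, and "the series" means these few. Any claim that something is new, unique, unknown or untested is made for them only; others in the source may bear on it.

Measured in an ADME assay on BCBL1 cells (Homo sapiens) for cytotoxicity, with a stated time of 7 days; on this read-out lower numbers stand for higher toxicity in this test and higher numbers for lower toxicity in this test:
Compound 1 `CC(C)CNc1nc(N)nc2c1ncn2/C=C1/CC1(CO)CO`: > 20000 nM, a limit of the assay.
Compound 2 `CCCOc1nc(N)nc2c1ncn2/C=C1/CC1(CO)CO`: > 20000 nM, a limit of the assay.
Compound 3 `CCCCCCSc1nc(N)nc2c1ncn2/C=C1/CC1(CO)CO`: > 20000 nM, a limit of the assay.

In this assay compound 3 stands at a limit, not at a number. All three measured compounds share that position (the limit of > 20000 nM in this assay, at which 3 of the 3 values shown sit). Compound 4 `Nc1nc(N2CCCC2)c2ncn(/C=C3/CC3(CO)CO)c2n1` differs from compound 3 in one place: pyrrolidin-1-yl in place of hexylsulfanyl on an aromatic carbon. For the measured compounds named here, the two steps leading into compound 3, a step that the two limits leave unreadable from compound 1 to compound 3 and a step that the two limits leave unreadable from compound 2 to compound 3, are both unreadable, so no measured step tells how far this kind of change shifts the read-out. Compound 4 is therefore expected to sit at the same limit, with an estimate of 20000 nM in a range from 10000 nM to 40000 nM. The expected step is a number no higher from compound 3 to compound 4 (the limit leaves the size open), none beyond the scatter.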

Compound 4, half-maximal cytotoxic concentration: > 20000 nM
Compound 4 was reported as a limit; the forecaster's own chance of this, stated with the estimate: 85%; the middle value sits exactly at the limit.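

In this assay compound 4 gives > 20000 nM, a limit of the assay, so its steps from compound 1, compound 2 and compound 3 cannot be read: the limit of > 20000 nM in this assay, at which 4 of the 4 values shown sit.

The compounds shown leave open where the half-maximal cytotoxic concentration of any of them actually lies, and whether changing the group on the aromatic carbon shifts it.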